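The source may hold more compounds than are shown below. What is called first, only, known or untested is meant among the compounds shown, and "the series" means these compounds.

Series notes, read in a functional assay on MCF7 cells (Homo sapiens) for antiproliferative activity, read by MTT assay, with a stated time of 48 h; on this read-out lower numbers stand for stronger inhibition and higher numbers for weaker inhibition. Going by the values given here, compound 2 `CCC(C)C(CO)NC(=O)c1ccc(C(CC)(CC)c2ccc(OCCC(O)(CC)CC)c(C)c2)n1CC` gives 29100 nM, the higher of the two numbers so far, while compound 1 `CCOC(=O)C(CC(=O)OC)NC(=O)c1ccc(C(CC)(CC)c2ccc(OCCC(O)(CC)CC)c(C)c2)n1CC` gives 390 nM. The next structure is compound 3 `CCn1c(C(=O)NC(CO)CCO)ccc1C(CC)(CC)c1ccc(OCCC(O)(CC)CC)c(C)c1`, with this change from compound 2: 2-hydroxyethyl in place of sec-butyl on a saturated chain carbon bound to an amide-type nitrogen and a saturated chain carbon. In words, 2-hydroxyethyl stands in place of sec-butyl on a saturated chain carbon bound to an amide-type nitrogen and a saturated chain carbon.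

Among the compounds with values here, only one measured step bears on this: a 75-fold higher number from compound 1 to compound 2 (1.87 log units; beyond the scatter). It is large and beyond the scatter, and it also falls on the group at the amide-type nitrogen. In that single pair, the lower number goes with the group holding more oxygen. Compound 3 gains oxygen in the same region but does not carry the full group of compound 1, and one pair gives only weak guidance. A partial recovery is therefore expected, not a full one. The estimated step is a 3.2-fold lower number from compound 2 to compound 3 (0.51 log units; beyond the scatter), toward a lower number and smaller than the measured step. For compound 3 the expected value is 9000 nM, with an estimated range of 1500 nM to 45000 nM.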

Compound 3, half-maximal inhibitory concentration: 31400 nM
Estimate against measurement, compound 3: 3.5-fold (0.54 log units) below; the measured number falls inside the stated range.
By their numbers in this assay, from the lowest: compound 1; then compounds 2 and 3 (each within the scatter of the next).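

In this assay, 2-hydroxyethyl in place of sec-butyl on this saturated chain carbon gives a 1.1-fold higher number from compound 2 to compound 3 (0.03 log units; within the scatter), so this change does not separate compound 2 from compound 3 and the oxygen it adds does not by itself go with a lower number. The larger group of compound 1 remains clearly apart, with an 81-fold higher number from compound 1 to compound 3 (1.91 log units; beyond the scatter), which shows that the oxygen-bearing group of compound 3 does not carry over the number seen with the group on the amide-type nitrogen of compound 1. Nothing measured on hand gives a reason for either result.

Open, on these data alone, is which part of the group in compound 1 goes with its lower number, since that group differs from those of compound 2 and compound 3 in more than one feature, including its ethyl ester and methyl ester. A carboxylic acid in place of either ester, or an amine or longer chain on the same saturated carbon, would test whether the number follows the esters or some other part of that group.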